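This account rests on a few compounds, and the source may have more. Where it says the series, first, only, none or still open, it means among the compounds named here.

Measured compounds in a functional assay for antagonist activity at melanin-concentrating hormone receptor 1 (Homo sapiens); on this read-out higher numbers stand for weaker inhibition and lower numbers for stronger inhibition:
Compound 1 `CCO/N=C/c1cccc([C@]23CCC(N(CCN(C(C)C)C(C)C)C(=O)Nc4ccc(F)c(Cl)c4)CC2C3)c1` gives 29 nM.
Compound 2 `CC(C)N(CCN(C(=O)Nc1ccc(F)c(Cl)c1)C1CC[C@]2(c3cccc(CNS(C)(=O)=O)c3)CC2C1)C(C)C` gives 18 nM.
Compound 3 `CCN(CC)Cc1cccc([C@]23CCC(N(CCN(C(C)C)C(C)C)C(=O)Nc4ccc(F)c(Cl)c4)CC2C3)c1` gives 46 nM.

Compound 3 has the highest number of the three; its gap to compound 1 is within the scatter, while a 2.6-fold higher number from compound 2 to compound 3 (0.41 log units; beyond the scatter) lies beyond it. Compound 4 `CC(C)N(CCN(C(=O)Nc1ccc(F)c(Cl)c1)C1CC[C@]2(c3cccc(CN(C)C)c3)CC2C1)C(C)C` differs from compound 3 by dimethylamino in place of diethylamino on a saturated chain carbon bound to an aromatic carbon. Going by the values given here, the one measured step at this position, a 2.6-fold higher number from compound 2 to compound 3 (0.41 log units; beyond the scatter), exchanged the entire group, whereas here only a part of it is trimmed, and a 1.6-fold higher number from compound 1 to compound 3 (0.20 log units; within the scatter) shows that rather different groups at this position leave the number within the scatter. No step beyond the scatter is therefore expected in this assay, and compound 4 is estimated at 35 nM, within 15 nM to 80 nM. This corresponds to an expected 1.3-fold lower number from compound 3 to compound 4 (0.12 log units; within the scatter).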

Compound 4, inhibition constant: 13 nM
Compound 4: middle estimate off by 2.7-fold (0.43 log units), on the high side; the whole stated range lies above it.
By their numbers in this assay, from the lowest: compounds 4, 2, 1 and 3 (each within the scatter of the next, the first and the last beyond it).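

In this assay, trimming diethylamino to dimethylamino gives a 3.5-fold lower number from compound 3 to compound 4 (0.55 log units; beyond the scatter), so at this position even a change within the amine, from ethyl to methyl groups, can move the number beyond the scatter. Dimethylamino also gives a 2.2-fold lower number from compound 1 to compound 4 (0.35 log units; beyond the scatter), while a 1.4-fold lower number from compound 2 to compound 4 (0.14 log units; within the scatter) shows that dimethylamino and methanesulfonamido cannot be told apart here. Nothing available explains why this change moves the number. The compounds shown leave open how a ring amine such as pyrrolidine, or a methylamino group, would read at this position.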